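This account rests on a few compounds, and the source may have more. Where it says the series, first, only, none or still open, it means among the compounds named here.

Measured so far in a functional assay on MCF7 cells (Homo sapiens) for cytotoxicity, read by MTT assay, with a stated time of 48 h; a higher number here means a weaker inhibitor, a lower number a stronger inhibitor:
Compound 1, `O=[N+]([O-])c1ccc2[nH]c(CSCc3nc4cc([N+](=O)[O-])ccc4[nH]3)nc2c1`: 1740 nM
Compound 2, `O=C(CSCc1nc2cc([N+](=O)[O-])ccc2[nH]1)c1ccc(Br)cc1`: 1550 nM
Compound 3, `O=C(CSCc1nc2cc([N+](=O)[O-])ccc2[nH]1)N/N=C/c1ccc(Cl)cc1`: 13700 nM

Compound 2 has the lowest number of the three. Its number and that of compound 1 lie within the scatter, so nothing separates them, while compound 3 sits well beyond the scatter from compound 2 with a clearly higher number. Compound 4, `CC1=NN(C(=O)CSCc2nc3cc([N+](=O)[O-])ccc3[nH]2)C(=O)C1`, has not been measured. It differs from compound 2 by a group of 7 heavy atoms (4 carbon, 2 nitrogen, 1 oxygen; one five-membered non-aromatic ring with 2 hetero atoms) in place of a group of 7 heavy atoms (6 carbon, 1 bromine; one six-membered aromatic ring of carbon only), on a carbonyl carbon. Among the measured compounds shown here, no measured pair shows a change of this kind, so the size of the step is uncertain. Compound 3, whose carbonyl also bears a nitrogen-containing group rather than a benzene ring, gives 13700 nM, which hints that such a change may cost potency. Compound 4 is therefore expected to give a higher number than compound 2, a step of a 3.9-fold higher number from compound 2 to compound 4 (0.59 log units; beyond the scatter) that is expected to reach beyond the scatter. The expected value for compound 4 is 6000 nM, with a range from 1500 nM to 25000 nM.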

Compound 4, half-maximal inhibitory concentration: 8070 nM
Compound 4: the middle estimate sits 1.3-fold (0.13 log units) below what was measured, within the range that was stated.
By their numbers in this assay, from the lowest: compounds 2 and 1 (each within the scatter of the next); then compounds 4 and 3 (each within the scatter of the next).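

Among the compounds shown here, on the carbonyl carbon, this is the first single change that can be read: in this assay, putting the five-membered non-aromatic ring group in place of 4-bromophenyl gives a 5.2-fold higher number from compound 2 to compound 4 (0.72 log units; beyond the scatter) and so weakens the compound beyond the scatter. The two groups have the same count of heavy atoms, so that count alone does not set the number at this position. Nothing measured here explains the step.

Going by these compounds, it remains open whether the loss follows the bromine or the aromatic ring. A plain phenyl group on the same carbonyl carbon would separate those two, while a simple amine there would test a nitrogen link without a ring.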